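A butyl amine to a cyclobutyl amide

The source may report more compounds than this note shows. Statements on the series, on what has been measured and on what is new or still open speak of the compounds shown alone.

Of the compounds shown here, two have been measured so far in an assay on HEK293 cells for positive allosteric modulation of metabotropic glutamate receptor 5 (Homo sapiens), read by FLIPR, with a stated time of 1 h; a higher number here means that more compound is needed for the effect, a lower number that less compound is needed.

Compound 1 `O=C1NCCc2nc(C#Cc3ccccc3)sc21` gives 112 nM.
Compound 2 `CCCCN1CCc2nc(C#Cc3ccccc3)sc2C1` gives 110 nM.

Compound 2 stands together with compound 1: the two numbers fall within the usual scatter of each other, so nothing separates them. Compound 3 `CC1CC(C(=O)N2CCc3nc(C#Cc4ccccc4)sc3C2)C1` keeps the core of compound 2 and differs in one place: (3-methylcyclobutyl)carbonyl in place of butyl on an amine nitrogen in a ring. Among the compounds with values here, no pair of measured compounds shows how a single change moves this read-out, so the size of this step has to be judged from the two values alone. Compound 1 at 112 nM and compound 2 at 110 nM sit side by side although one holds a carbonyl in the ring and the other does not, which suggests the core tolerates such a change. The expected step is no change at the digits printed from compound 2 to compound 3 (within the scatter), no larger than the scatter in either direction. Compound 3 is therefore estimated at 110 nM, within a range from 35 nM to 350 nM.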

Compound 3, half-maximal effective concentration: 81 nM
The estimate for compound 3 lay 1.4-fold (0.13 log units) above the measured number; measured number inside the range.
By their numbers in this assay, from the lowest: compounds 3, 2 and 1 (each within the scatter of the next).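

On the amine nitrogen in the ring, this assay shows a 1.4-fold lower number from compound 2 to compound 3 (0.13 log units; within the scatter) when butyl gives way to (3-methylcyclobutyl)carbonyl. This position therefore holds a larger group carrying a four-membered ring and a hydrogen-bond acceptor, with the amine now an amide, and the read-out stays within the scatter; compounds 1 and 2 differ in more than one place, so they could not show this. No measurement shown explains why the two groups read alike.

The compounds shown leave open which part of the new group matters, since the carbonyl and the ring enter together. A pentanoyl group would carry the carbonyl without the ring, a cyclobutylmethyl group would carry the ring without the carbonyl, and either could separate the two.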